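Swapping a methoxy-bearing ring for a fluorinated one

The compounds below may be only part of what the source reports. "The series", "measured", "known", "first", "only" and "open" are said of these compounds alone.

Compound 1 `COc1ccc(C2OC(c3cc(OC)c(OC)c(OC)c3)=NN2C(C)=O)c(OC)c1` was tested in a functional assay on PC-3 cells (Homo sapiens) for antiproliferative activity, read by MTT assay, tested at 1 uM (a higher number here means a stronger effect of the compound at the concentration tested, a lower number a weaker effect), where compound 1 gives 69.5%. Among the compounds with values here, this is the highest of the two numbers so far; the nearest is compound 2 `COc1cc(C(=O)N/N=C/c2ccc(Cl)c([N+](=O)[O-])c2)cc(OC)c1OC`, which in this assay gives 32.1%, a gap beyond the usual scatter. Compound 2 is built on a different framework, so its value says nothing about a single change on the core of compound 1.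

Compound 3 `COc1cc(C2=NN(C(C)=O)C(c3ccc(F)c(F)c3)O2)cc(OC)c1OC` has not yet been measured. It differs from compound 1 in one place: 3,4-difluorophenyl in place of 2,4-dimethoxyphenyl on a saturated ring carbon. Within the data shown here, no measured pair shows such a change, and the leaving group carries the two hydrogen-bond acceptors that the entering group lacks; how much that matters is unknown. A moderate step downward, probably beyond the scatter, is expected: a number 19.5 percentage points lower from compound 1 to compound 3 (beyond the scatter). Compound 3 is therefore expected to give 50%, within 25% to 72%.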

Compound 3, a percentage reported as inhibition, at one concentration (the size of the read-out at that concentration, not a potency): 35.5%
For compound 3 the middle estimate is 14.5 percentage points above the measured one, and the stated range covers the measured number.
By their numbers in this assay, from the lowest: compounds 2 and 3 (each within the scatter of the next); then compound 1.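

Within the data shown here, this is the first measured change on the saturated ring carbon, and it shows that the read-out responds to which aromatic ring sits there. In this assay, putting 3,4-difluorophenyl in place of 2,4-dimethoxyphenyl gives a number 34 percentage points lower from compound 1 to compound 3 (beyond the scatter) on an otherwise unchanged core, so this position is not indifferent to the swap. No measurement at hand explains the step, and the data cannot separate the departure of the two methoxy groups from the arrival of the two fluorines.

Among these compounds, with only this one swap, it remains open whether the methoxy groups or the fluorines matter more, and a ring carrying just one methoxy group or just one fluorine could help to tell them apart. From the compounds shown here alone, how a ring bearing a dimethylamino group or a carboxylic acid would behave at this position also remains open.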